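The source may hold more compounds than are shown below. What is called first, only, known or untested is meant among the compounds shown, and "the series" means these compounds.

For the measured compounds named here, compound 1 `CNC(=O)CCCCCCCn1nc(-c2ccc3oc(N)nc3c2)c2c(N)ncnc21` gives the one number in a functional assay on HepG2 cells (Homo sapiens) for inhibition, read by MTT assay, with a stated time of 72 h (on this read-out lower numbers stand for stronger inhibition and higher numbers for weaker inhibition), where compound 1 reads 3640 nM. Compound 2 `Nc1nc2cc(-c3nn(CCCC(=O)NO)c4ncnc(N)c34)ccc2o1` returns only the limit > 50000 nM in this assay. Going by the values given here, the single measured step, an at least 13-fold higher number from compound 1 to compound 2 (1.13 log units; beyond the scatter), ends at the limit of > 50000 nM in this assay, at which 1 of the 2 values shown sits. Compound 3 `Nc1nc2cc(-c3nn(CCCCCCC(=O)NO)c4ncnc(N)c34)ccc2o1` differs from compound 1 by hydroxycarbamoyl in place of (methylcarbamoyl)methyl on a saturated chain carbon, six bonds along the chain from an aromatic nitrogen; read one bond further out, the same change is 4-(methylcarbamoyl)butyl to 3-(hydroxycarbamoyl)propyl. The measured step bears on this: it likewise puts hydroxycarbamoyl in place of a methylcarbamoyl-ended chain on a saturated chain carbon, but three bonds along the chain from the aromatic nitrogen, and it reads an at least 13-fold higher number from compound 1 to compound 2 (1.13 log units; beyond the scatter). Compound 3 keeps hydroxycarbamoyl six bonds along the chain from the aromatic nitrogen, and the expected loss is smaller than that step yet still beyond the scatter, an estimated 2.5-fold higher number from compound 1 to compound 3 (0.39 log units; beyond the scatter). Compound 3 is therefore expected at 9000 nM in this assay, between 2500 nM and 35000 nM, with a real chance that only a limit is returned.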

Compound 3, half-maximal inhibitory concentration: 1610 nM
Beside the measured number, compound 3's estimate is 5.6-fold (0.75 log units) above it; measured number below the stated range.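

With the hydroxycarbamoyl end kept, chain length now emerges as decisive in this assay: an at least 31-fold lower number from compound 2 to compound 3 (1.49 log units; beyond the scatter), with 3-(hydroxycarbamoyl)propyl in place of hydroxycarbamoyl at the position three bonds along the chain from an aromatic nitrogen. The reading for compound 2 is a limit, so the size of this step is a bound rather than a measured gap: the limit of > 50000 nM in this assay, at which 1 of the 3 values shown sits. Hydroxycarbamoyl six bonds along the chain from an aromatic nitrogen also brings no loss against the methylcarbamoyl-ended chain, giving instead a modest gain beyond the scatter, a 2.3-fold lower number from compound 1 to compound 3 (0.35 log units; beyond the scatter), so the loss seen on the short chain does not carry over to the longer one.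

For the compounds shown here, with only two hydroxycarbamoyl chain lengths in hand, it remains open whether a longer chain than that of compound 3 would lower the number further or raise it again. Also open, going by these compounds, is whether a carboxylic acid or a primary amide at the chain end would read like hydroxycarbamoyl or like the methylcarbamoyl end of compound 1.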